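Methoxy for Chloro on the Aromatic Ring

This account rests on a few compounds, and the source may have more. Where it says the series, first, only, none or still open, it means among the compounds named here.

In an assay on RBL-1 cells for inhibition of Polyunsaturated fatty acid 5-lipoxygenase (Rattus norvegicus) (a lower number here means a stronger inhibitor, a higher number a weaker inhibitor), compound 3 `CC1CN(c2cccc(Cl)n2)NC(=O)N1` gives 3500 nM, and its number stands within the scatter of the other two: compound 2 `O=C1NCCN(c2cccc(Cl)n2)N1` gives 5600 nM and compound 1 `CCC1CN(c2ccccc2)NC(=O)N1` gives 6900 nM. Compound 4 `COc1cccc(N2CC(C)NC(=O)N2)n1` differs from compound 3 by methoxy in place of chloro on an aromatic carbon. Within the data shown here, no measured step bears on this aromatic substituent; the only step among the three, a 1.6-fold lower number from compound 2 to compound 3 (0.20 log units; within the scatter), concerns a saturated ring carbon and gives no guide here. Among the measured compounds shown here, with no precedent for the exchange, compound 4 is expected to stay close to compound 3, so that the step from compound 3 to compound 4 amounts to no change at the digits printed from compound 3 to compound 4 (within the scatter) in this assay. The estimate for compound 4 is therefore 3500 nM, with a range from 1500 nM to 8000 nM.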

Compound 4, half-maximal inhibitory concentration: 5500 nM
For compound 4 the middle estimate is 1.6-fold (0.20 log units) below the measured one, and the stated range covers the measured number.
By their numbers in this assay, from the lowest: compounds 3, 4, 2 and 1 (each within the scatter of the next).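

In this assay, among these compounds, the exchange on the aromatic carbon next to the ring nitrogen gives a 1.6-fold higher number from compound 3 to compound 4 (0.20 log units; within the scatter), the first measured step at this substituent. The position thus takes methoxy, with its two heavy atoms and one hydrogen-bond acceptor, in place of chloro without a step beyond the scatter. No evidence at hand accounts for this result.

Going by these compounds, whether an amine, a carboxylic acid or a longer alkoxy chain on this carbon would also stay within the scatter of compound 3 remains open. So does whether methoxy would give a similar number with hydrogen in place of the ring methyl, as in compound 2.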